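The compounds below may be only part of what the source reports. "The series", "measured", "known", "first", "only" and "open" are said of these compounds alone.

Measured compounds:
compound 1, `Cc1ccc(C(=O)Nc2ccc(Cl)cc2C(N)=O)cc1`: in a functional assay on HeLa cells (Homo sapiens) for antiproliferative activity, read by MTT assay, with a stated time of 48 h (a lower number here means a stronger inhibitor, a higher number a weaker inhibitor), compound 1 gives 8.23 ug/mL.
compound 2, `Cc1ccc(-c2nc3ccc(Cl)cc3c(=S)n2N)cc1`: compound 2 gives 14 ug/mL.
compound 3, `Cc1ccc(-c2nc(SCc3ccccc3)c3cc(Cl)ccc3n2)cc1`: compound 3 gives 11.3 ug/mL.

The three values lie close together. Compound 3 sits between the other two, and its gaps to compound 2 and to compound 1 both fall within the usual scatter, so the three compounds read as equivalent on these numbers. Among the measured compounds shown here, no two of them differ at a single place, so no one-point step is available as a yardstick.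

Compound 4, `Cc1ccc(-c2nc(SCCO)c3cc(Cl)ccc3n2)cc1`, is the next member. It differs from compound 3 by hydroxymethyl in place of phenyl on a saturated chain carbon bound to a sulfur. For the measured compounds named here, nothing measured so far speaks to this kind of exchange on the sulfur chain; compounds 1, 2 and 3 differ from one another in other parts of the structure. The expectation is therefore for a step within the scatter, with at most a slight lean toward a weaker number. For compound 4 the estimated value is 15 ug/mL, with a range from 6 ug/mL to 40 ug/mL. The expected step reads a 1.3-fold higher number from compound 3 to compound 4 (0.12 log units; within the scatter).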

Compound 4, half-maximal inhibitory concentration: 9.25 ug/mL
Compound 4: the middle estimate sits 1.6-fold (0.21 log units) above what was measured; low and high end bracket the measured number.
By their numbers in this assay, from the lowest: compounds 1, 4, 3 and 2 (each within the scatter of the next).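

In this assay, among the compounds shown here, hydroxymethyl in place of phenyl on a saturated chain carbon bound to a sulfur gives the first one-place step (a 1.2-fold lower number from compound 3 to compound 4 (0.09 log units; within the scatter)). At this position, benzylsulfanyl and (2-hydroxyethyl)sulfanyl read as equivalent: the six-membered aromatic ring of carbon can leave and a hydrogen-bond donor and acceptor can enter with no readable shift in the number. No measurement at hand gives a reason for this equivalence.

This single step cannot show whether the equivalence extends to other groups at the end of the chain, such as an amine, a carboxylic acid or a longer chain. Going by these compounds, the role of the sulfur itself also stays open, as compound 3 and compound 4 both carry it, and an oxygen link in its place would test that.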